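Solubility notes: chloropyridinyl amide in place of benzamide

This account rests on a few compounds, and the source may have more. Where it says the series, first, only, none or still open, it means among the compounds named here.

Among the compounds with values here, compound 1 `O=C(c1ccccc1)N1CCC(NS(=O)(=O)c2cc(S(=O)(=O)c3ccccc3)ccc2C(F)(F)F)CC1` gives 12500 nM in a physicochemical assay for solubility (a lower number here means a less soluble compound, a higher number a more soluble compound), the highest of the two numbers measured so far. Compound 2 `O=C(c1ccc(Cl)cc1)N1CCC(NS(=O)(=O)c2cc(S(=O)(=O)c3ccccc3)ccc2C(F)(F)F)CC1` gives 3100 nM, the step of a 4.0-fold lower number from compound 1 to compound 2 (0.61 log units; beyond the scatter). Compound 3 `O=C(c1ccc(Cl)nc1)N1CCC(NS(=O)(=O)c2cc(S(=O)(=O)c3ccccc3)ccc2C(F)(F)F)CC1` carries the change (6-chloropyridin-3-yl in place of phenyl on a carbonyl carbon). Within the data shown here, the only measured step that bears on it is the chloro step; the ring nitrogen has no measured counterpart, so its share of the step is open. A lower number is therefore expected for compound 3, but its size is uncertain: the estimated step is a 2.5-fold lower number from compound 1 to compound 3 (0.40 log units; beyond the scatter). Compound 3 is thus expected at 5000 nM, within 2000 nM to 15000 nM.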

Compound 3, solubility: 25000 nM
The estimate for compound 3 lay 5.0-fold (0.70 log units) below the measured number; measured number above the stated range.
By their numbers in this assay, from the lowest: compound 2; then compounds 1 and 3 (each within the scatter of the next).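

With 6-chloropyridin-3-yl in place of phenyl on a carbonyl carbon, this assay gives a 2.0-fold higher number from compound 1 to compound 3 (0.30 log units; within the scatter), so a chlorine-bearing ring need not bring the lower number seen with compound 2. Within the data shown here, with 6-chloropyridin-3-yl in place of 4-chlorophenyl, the read-out shows an 8.1-fold higher number from compound 2 to compound 3 (0.91 log units; beyond the scatter), the first measured step at this position that separates two chlorine-bearing rings. No measurement shown gives a cause for this difference.

From the compounds shown here alone, the contribution of the chlorine on the pyridine ring remains open, as the plain pyridin-3-yl amide would show. Going by these compounds, whether a methyl or methoxy group in place of that chlorine would keep the number also remains open.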